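Chloro in place of methoxy: expectation for compound 4

The source may hold more compounds than are shown below. What is called first, only, known or untested is meant among the compounds shown, and "the series" means these compounds.

Compound 1 `COc1ccc(C2=NN(C3=NC(=O)/C(=C4\C(=O)Nc5ccc(Br)cc54)S3)C(c3ccc(OC)cc3)C2)cc1` gives 710 nM in a functional assay on cells (Cancer cell lines, Homo sapiens) for cytotoxicity, read by sulforhodamine B assay, with a stated time of 48 h; a higher number here means a weaker inhibitor of growth, a lower number a stronger inhibitor of growth. Compound 2 `COc1ccc(C2=NN(C3=NC(=O)/C(=C4\C(=O)Nc5ccc(Cl)cc54)S3)C(c3ccc(OC)cc3)C2)cc1` gives 710 nM and compound 3 `COc1ccc(C2CC(c3ccc4ccccc4c3)=NN2C2=NC(=O)/C(=C3\C(=O)Nc4ccc(Br)cc43)S2)cc1` gives 510 nM; compound 1 stands level with compound 2 and within the scatter of compound 3, so the three numbers do not separate. Compound 4 `COc1ccc(C2=NN(C3=NC(=O)/C(=C4\C(=O)Nc5ccc(Br)cc54)S3)C(c3ccc(Cl)cc3)C2)cc1` differs from compound 1 in one place (chloro in place of methoxy on an aromatic carbon). Going by the values given here, no measured step makes this exact change. The two steps available, no change at the digits printed from compound 1 to compound 2 (within the scatter) and a 1.4-fold lower number from compound 1 to compound 3 (0.14 log units; within the scatter), each alter one group on the shared core without moving the number beyond the scatter, which suggests a further change of this kind is unlikely to do so either. Compound 4 is therefore expected at 710 nM, with a range of 350 nM to 1400 nM. The step of no change at the digits printed from compound 1 to compound 4 (within the scatter) is expected to stay within the scatter.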

Compound 4, concentration for total growth inhibition: 1010 nM
Estimate against measurement, compound 4: 1.4-fold (0.15 log units) below, within the range that was stated.
By their numbers in this assay, from the lowest: compounds 3, 1, 2 and 4 (each within the scatter of the next).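

In this assay, exchanging the methoxy group for chloro, para to a large group, gives a 1.4-fold higher number from compound 1 to compound 4 (0.15 log units; within the scatter). Going by these compounds alone, this position therefore keeps the number within the scatter when the methoxy group and its hydrogen-bond acceptor are replaced by chloro, a change at a site the earlier steps left untouched. No measurement shown here accounts for this result.

From the compounds shown here alone, whether an amine or a carboxylic acid at this position would move the number beyond the scatter remains open. So does the effect of a longer chain there.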